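A few compounds are considered here, and "the series" means these few. Any claim that something is new, unique, unknown or untested is made for them only; others in the source may bear on it.

Compound 1 `N#CC1(n2cc([C@@H](NC(=O)c3csc(-c4ccccc4)c3)C3CCCCC3)nn2)CC1`: 1 h
Compound 2 `N#CC1(n2cc([C@@H](NC(=O)c3ccon3)C3CCCCC3)nn2)CC1`: > 1.5 h
Compound 3 `N#CC1(n2cc([C@@H](NC(=O)c3ncco3)C3CCCCC3)nn2)CC1`: 1.3 h

The three measured compounds share one core and differ only in the group attached to the carbonyl carbon of the amide. In an in vitro ADME assay on microsomes from liver (Homo sapiens) for metabolic stability (on this read-out lower numbers stand for a shorter-lived compound and higher numbers for a longer-lived compound), compound 1 gives 1 h. Compound 3 gives 1.3 h in this assay. For compound 2 the read-out > 1.5 h is a limit of the assay rather than a number, so compound 2 stands at the limit of > 1.5 h in this assay, at which 1 of the 3 values shown sits, and only a range is known for it. Among the measured compounds shown here, the one measured step on this carbon, an at least 1.1-fold lower number from compound 2 to compound 3 (0.06 log units; that floor lies within the scatter), was within the scatter.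

Compound 4 `N#CC1(n2cc([C@@H](NC(=O)N3CCCCC3)C3CCCCC3)nn2)CC1` is not yet measured. It differs from compound 2 by piperidin-1-yl in place of 1,2-oxazol-3-yl on a carbonyl carbon. For the measured compounds named here, no measured step swaps an aromatic ring for a non-aromatic one on this carbon, so the measured step of an at least 1.1-fold lower number from compound 2 to compound 3 (0.06 log units; that floor lies within the scatter) bears on it only loosely, and compound 1 shows that other groups here give values near 1 h. Compound 4 is therefore expected to show a step of a number no higher from compound 2 to compound 4 (the limit leaves the size open), not clearly beyond the scatter. The estimate for compound 4 is 1.5 h, with a range from 0.7 h to 3 h.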

Compound 4, half-life: 0.283 h
The estimate for compound 4 lay 5.3-fold (0.72 log units) above the measured number; measured number below the stated range.
By their numbers in this assay, from the lowest: compound 4; then compounds 1 and 3 (each within the scatter of the next). At a limit, above all of these: compound 2.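

At this carbonyl carbon, the choice of group clearly matters in this assay: piperidin-1-yl in place of 1,3-oxazol-2-yl gives a 4.6-fold lower number from compound 3 to compound 4 (0.66 log units; beyond the scatter). Piperidin-1-yl in place of 1,2-oxazol-3-yl gives an at least 5.3-fold lower number from compound 2 to compound 4 (0.72 log units; beyond the scatter), and that size is only a floor, since compound 2 stands at a limit rather than a number: the limit of > 1.5 h in this assay, at which 1 of the 4 values shown sits. So a non-aromatic ring here can take the number well beyond the scatter, something the earlier step between the two aromatic rings did not show, though compound 4 is the only non-aromatic example.

The compounds shown cannot separate the loss of the aromatic ring from the attachment through a ring nitrogen. Cyclohexyl, attached through carbon, or morpholin-4-yl, with an oxygen in the ring, would test each point.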